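The source may report more compounds than this note shows. Statements on the series, on what has been measured and on what is new or still open speak of the compounds shown alone.

Compound 1 `Cc1c2cc[n+](C)cc2c(C)c2c3c([nH]c12)C=CC(=O)[C@@]31O[C@@H]2[C@H](O1)[C@@H](CO)O[C@H]2n1cnc2c(N)ncnc21` stands as the only plain number shown in this set. In a functional assay on L1210 cells (Mus musculus) for cytotoxicity (on this read-out lower numbers stand for stronger inhibition and higher numbers for weaker inhibition), compound 1 gives 0.8 uM. Compound 2 `Cc1c2cc[n+](C)cc2c(C)c2c3c([nH]c12)C=CC(=O)[C@@]31O[C@@H]2[C@H](O1)[C@@H](COP(=O)(O)O)O[C@H]2n1cnc2c(N)ncnc21` differs from compound 1 by a group of 4 heavy atoms (3 oxygen, 1 phosphorus; no ring) in place of a hydrogen atom, on an oxygen on a saturated carbon. For compound 2 this assay reports only a limit, > 0.8 uM. The step of a number no lower from compound 1 to compound 2 (the limit leaves the size open) has no readable size, since one of the two values sits at the limit (the limit of > 0.8 uM in this assay, at which 1 of the 2 values shown sits). Compound 3 `Cc1c2cc[n+](C)cc2c(C)c2c3c([nH]c12)C=CC(=O)[C@@]31O[C@@H]2[C@H](O1)[C@@H](CO)O[C@H]2n1ccc(=O)[nH]c1=O` differs from compound 1 in another place: a group of 8 heavy atoms (4 carbon, 2 nitrogen, 2 oxygen; one six-membered aromatic ring with 2 hetero atoms) in place of a group of 10 heavy atoms (5 carbon, 5 nitrogen; one five-membered aromatic ring with 2 hetero atoms, one six-membered aromatic ring with 2 hetero atoms), on a saturated ring carbon. Among the measured compounds shown here, no measured step touches that part of the structure, and the measured step from compound 1 to compound 2 gives no guide to its size or direction. A step toward weaker inhibition is nonetheless expected, of about a 3.8-fold higher number from compound 1 to compound 3 (0.57 log units; beyond the scatter). Compound 3 is therefore estimated at 3 uM in this assay, with a range from 0.8 uM to 15 uM.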

Compound 3, concentration for 50% inhibition: > 3 uM
Compound 3: only a limit was reported; the forecaster's own chance of this, stated with the estimate: 40%; the middle value lies on the limit itself.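

In this assay, replacing the group with a five-membered and a six-membered aromatic ring by the group with a single six-membered aromatic ring, on the saturated ring carbon next to the ring oxygen, gives an at least 3.7-fold higher number from compound 1 to compound 3 (0.57 log units; beyond the scatter). Compound 3 has only a limit, > 3 uM, and not a number: the limit of > 3 uM in this assay, at which 1 of the 3 values shown sits. Among the compounds shown here, the earlier step on the hydroxymethyl group could not be read, so this is the first change here with a direction and a minimum size, and it points to weaker inhibition.

The compounds shown do not separate the loss of the five-membered aromatic ring from the arrival of the two double bonds outside aromatic rings. They also leave open how an amine or a carboxylic acid on that same carbon would behave in this assay.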